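Aryl replacement at the fused core and HepG2 cytotoxicity

The source may report more compounds than this note shows. Statements on the series, on what has been measured and on what is new or still open speak of the compounds shown alone.

Compound 2 `COc1ccc(F)cc1CNCCCNc1ccnc2cc(Oc3ccc(C(C)(C)C)cc3)ccc12` gives 7200 nM in an ADME assay on HepG2 cells (Homo sapiens) for cytotoxicity, read by luminescence, CellTiter-Glo and ATP content, with a stated time of 72 h; a higher number here means that more compound is needed for the effect, a lower number that less compound is needed. Among the measured compounds shown here, its only neighbour so far, compound 1 `COc1ccc(F)cc1CNCCCNc1ccnc2cc(CCc3ccccc3)ccc12`, gives 4240 nM in this assay, and the step of a 1.7-fold higher number from compound 1 to compound 2 (0.23 log units; within the scatter) lies within the scatter, so the two stand together. Compound 3 `COc1ccc(-c2ccc3c(NCCCNCc4cc(F)ccc4OC)ccnc3c2)cc1` carries 4-methoxyphenyl in place of 4-(tert-butyl)phenoxy on an aromatic carbon. For the measured compounds named here, that single step is the only guide for this change, and it was small, so there is no ground to expect a step beyond the scatter in this assay in either direction. For compound 3 the value expected in this assay is 5500 nM, with a range from 2500 nM to 12000 nM, an estimated step of a 1.3-fold lower number from compound 2 to compound 3 (0.12 log units; within the scatter).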

Compound 3, half-maximal effective concentration: 5960 nM
Compound 3: middle estimate off by 1.1-fold (0.03 log units), on the low side; low and high end bracket the measured number.
By their numbers in this assay, from the lowest: compounds 1, 3 and 2 (each within the scatter of the next).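

In this assay, 4-methoxyphenyl at this aromatic carbon joins the two earlier groups without separating from either: a 1.2-fold lower number from compound 2 to compound 3 (0.08 log units; within the scatter) and a 1.4-fold higher number from compound 1 to compound 3 (0.15 log units; within the scatter). Phenethyl, 4-(tert-butyl)phenoxy and 4-methoxyphenyl therefore stand together here, so this read-out does not tell the three groups apart. No evidence at hand bears on this result.

Open, as far as these compounds go, is whether a group of another kind at this position, such as an amine or a carboxylic acid, would give a step beyond the scatter in this assay.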